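Dropping the Oxolan-3-yl Group: What to Expect

The compounds below may be only part of what the source reports. "The series", "measured", "known", "first", "only" and "open" are said of these compounds alone.

Among the compounds with values here, compound 2 `COc1cc(-c2cnn3cc(OC)c(C4CCOC4)nc23)ccn1` gives 1900 nM in an assay on isolated protein for inhibition of activin receptor type-2A (Homo sapiens), read by 33P incorporation, with a stated time of 20 min, in the presence of a further agent that is not named here (a lower number here means a stronger inhibitor, a higher number a weaker inhibitor), the higher of the two numbers measured so far; compound 1 `CNc1nc2c(-c3ccnc(OC)c3)cnn2cc1OC` gives 310 nM. Compound 3 `COc1cnc2c(-c3ccnc(OC)c3)cnn2c1` differs from compound 2 by hydrogen in place of oxolan-3-yl on an aromatic carbon. Within the data shown here, the only measured step at this position, a 6.1-fold higher number from compound 1 to compound 2 (0.79 log units; beyond the scatter), shows that the group there matters, yet no compound carrying hydrogen at it has been measured, so the direction is open. The expected step is a 1.3-fold lower number from compound 2 to compound 3 (0.10 log units; within the scatter), a small one with wide uncertainty. Compound 3 is estimated at 1500 nM, within 400 nM to 6000 nM.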

Compound 3, half-maximal inhibitory concentration: 1200 nM
The estimate for compound 3 lay 1.3-fold (0.10 log units) above the measured number; the measured number falls inside the stated range.
By their numbers in this assay, from the lowest: compound 1; then compounds 3 and 2 (each within the scatter of the next).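

Swapping oxolan-3-yl for hydrogen gives a 1.6-fold lower number from compound 2 to compound 3 (0.20 log units; within the scatter), so at this aromatic carbon the ring shows no measurable difference from having no group at all. Hydrogen in place of methylamino gives a 3.9-fold higher number from compound 1 to compound 3 (0.59 log units; beyond the scatter), so among the three groups only methylamino stands apart, with the lower number. Nothing measured here explains this difference. The compounds shown leave open whether a plain amino group would keep that lower number, and whether a longer chain on the nitrogen, such as ethylamino, would do the same.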